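The source may report more compounds than this note shows. Statements on the series, on what has been measured and on what is new or still open speak of the compounds shown alone.

Measured so far:
compound 1 `Cc1ccc(S(=O)(=O)N[C@H]2CC[C@@H](F)[C@@H]2C/C=C\CCCC(=O)O)cc1` — 260 nM
compound 2 `Cc1ccc(S(=O)(=O)N[C@H]2CC[C@@H](F)[C@@H]2CCCCOCC(=O)O)cc1` — 1800 nM
compound 3 `O=C(O)CCC/C=C\CC1=CCC[C@@H]1NS(=O)(=O)c1ccccc1[N+](=O)[O-]` — 680 nM

In a functional assay on a cell-free system (plasma) for inhibition of thromboxane A2 receptor (Homo sapiens), read by turbidimetry (a lower number here means a stronger inhibitor, a higher number a weaker inhibitor), compound 1 gives the lowest number of the three. Among the measured compounds shown here, compound 3 sits next to it, and compound 2 is furthest off; the one single-point step, a 6.9-fold higher number from compound 1 to compound 2 (0.84 log units; beyond the scatter), concerns the acid-bearing chain and not the aryl group, so it does not bear on the change considered here.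

Compound 4 `O=C(O)CCC/C=C\C[C@H]1[C@H](F)CC[C@@H]1NS(=O)(=O)c1ccccc1[N+](=O)[O-]` is compound 1 with 2-nitrophenyl in place of 4-methylphenyl on a sulfonyl sulfur. For the measured compounds named here, no measured pair isolates this exchange. Compound 3 carries the same 2-nitrophenyl sulfonamide but on a different core without the fluorine, so its value and that of compound 1 show only that the combination of both changes ends up at a somewhat higher number; how much of that belongs to the aryl swap cannot be separated.

The expectation for compound 4 is therefore a small drift to a higher number, a 1.7-fold higher number from compound 1 to compound 4 (0.24 log units; within the scatter), possibly not beyond the scatter. The estimate for compound 4 in this assay is 450 nM, within 180 nM to 1200 nM.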

Compound 4, half-maximal inhibitory concentration: 1800 nM
Compound 4: the middle estimate sits 4.0-fold (0.60 log units) below what was measured; the measured number lies above the stated range.
By their numbers in this assay, from the lowest: compound 1; then compound 3; then compounds 2 and 4 (each within the scatter of the next).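

In this assay the group on the sulfonyl sulfur now proves to matter on the core of compound 1: 2-nitrophenyl in place of 4-methylphenyl gives a 6.9-fold higher number from compound 1 to compound 4 (0.84 log units; beyond the scatter) and so takes the series away from its lowest number. That step has the same printed size as a 6.9-fold higher number from compound 1 to compound 2 (0.84 log units; beyond the scatter) in the acid-bearing chain, so on this core the aryl exchange counts for as much as the chain exchange. Nothing available here accounts for the rise.

Still open, going by these compounds, is whether the rise goes with the entering nitro group or with the loss of the methyl group, and a plain phenyl on the sulfonyl sulfur would separate the two. Also open, on these data alone, is whether a methoxyphenyl or chlorophenyl there would stay close to compound 1.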